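The source may report more compounds than this note shows. Statements on the series, on what has been measured and on what is new or still open speak of the compounds shown alone.

Measured compounds in a functional assay on HL-60 cells (Homo sapiens) for inhibition, read by trypan blue exclusion, with a stated time of 72 h; a higher number here means a weaker inhibitor of growth, a lower number a stronger inhibitor of growth:

Compound 1, `C=C(CC)C(=O)c1ccc(OCc2nc(-c3ccc(C(F)(F)F)cc3)cs2)c(C)c1C`, gives 1500 nM.
Compound 2, `C=C(C)C(=O)c1ccc(OCc2nc(-c3ccc(C(F)(F)F)cc3)cs2)c(C)c1C`, gives 3100 nM.
Compound 3, `C=C(CC)C(=O)c1ccc(OCc2nc(-c3ccc4ccccc4c3)cs2)cc1Cl`, gives 900 nM.

Compound 1 and compound 2 share one core and differ in a single spot: hydrogen in place of methyl on a saturated chain carbon bound to a double-bonded chain carbon. This change brought a 2.1-fold higher number from compound 1 to compound 2 (0.32 log units; beyond the scatter), so in this pair the loss of the methyl went with a weaker inhibitor of growth.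

Compound 3 sits on a different core. How that core differs from the core of compound 1 is not broken down here. Its number is the lowest of the three measured, though its gap to compound 1 lies within the scatter, so the two cannot be ranked against each other; its gap to compound 2 lies beyond the scatter.

Compound 4, `C=C(C)C(=O)c1ccc(OCc2nc(-c3ccc4ccccc4c3)cs2)cc1Cl`, has not been measured. It stands to compound 3 exactly as compound 2 stands to compound 1: hydrogen in place of methyl on a saturated chain carbon bound to a double-bonded chain carbon. The place of the change is the same in both pairs, so this is the same change, made on the other core.

Going by the values given here, with only one measured instance of this change, the expectation rests on that single step. The step expected here is a 2.1-fold higher number from compound 3 to compound 4 (0.32 log units; beyond the scatter), and it is estimated by carrying over a 2.1-fold higher number from compound 1 to compound 2 (0.32 log units; beyond the scatter) onto the value of compound 3. Compound 4 is therefore expected to give about 1900 nM in this assay, with an estimated range from 900 nM to 4000 nM, the width reflecting that the carry-over from one pair to another is itself uncertain.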

Compound 4, concentration for 50% growth inhibition: 2900 nM
The estimate for compound 4 lay 1.5-fold (0.18 log units) below the measured number; the measured number falls inside the stated range.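

On the core of compound 3, the same swap of methyl for hydrogen, which shortens ethyl to methyl, gave a 3.2-fold higher number from compound 3 to compound 4 (0.51 log units; beyond the scatter) in this assay, so on this core too the shorter chain went with a weaker inhibitor of growth. Set beside the earlier pair, the change points the same way on both cores, and its size does not differ measurably between them: the same change on two cores in this assay, a 2.1-fold higher number (0.32 log units; beyond the scatter) from compound 1 to compound 2 and a 3.2-fold higher number (0.51 log units; beyond the scatter) from compound 3 to compound 4, 1.6-fold (0.19 log units) apart, within the scatter of two such steps. Going by these compounds alone, this shows that, for these two cores, a step measured on one core gave a fair guide to the step on the other, but with only two pairs it does not show that the change would behave the same way on any further core, and it says nothing about why the shorter chain goes with weaker inhibition.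

The compounds shown carry only ethyl or methyl at this place, so it remains open whether a longer chain such as propyl or butyl would continue the trend or reverse it, and what a hydroxyl group or an amine on that chain would do. From the compounds shown here alone, it also remains open whether the step would hold in any read-out other than this assay.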